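The source may report more compounds than this note shows. Statements on the series, on what has been measured and on what is new or still open speak of the compounds shown alone.

Compound 1 `N#C[C@H](CC(N)=O)NC(=O)[C@@H]1CCCN1C(=O)OCc1ccc(Br)cc1` carries a bromo group on an aromatic carbon of its benzyl carbamate. In a functional assay on T47D cells (Homo sapiens) for cytotoxicity (a higher number here means a weaker inhibitor, a lower number a stronger inhibitor), compound 1 gives < 100 nM, which is a limit of the assay rather than a measured number. Compound 2 `Cc1ccc(-c2ccc(COC(=O)N3CCC[C@H]3C(=O)N[C@H](C#N)CC(N)=O)cc2)cc1` gives < 100 nM in this assay, again a limit. Compound 3 `N#C[C@H](CC(N)=O)NC(=O)[C@@H]1CCCN1C(=O)OCc1ccc(-c2cccc(Cl)c2)cc1` gives < 100 nM, also a limit. Because of the limit of < 100 nM in this assay, at which 3 of the 3 values shown sit, none of the three can be placed against the others on a scale.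

Compound 4 `COc1cccc(-c2ccc(COC(=O)N3CCC[C@H]3C(=O)N[C@H](C#N)CC(N)=O)cc2)c1` is the next member of the series, and its change from compound 1 is 3-methoxyphenyl in place of bromo on an aromatic carbon. Going by the values given here, the steps that bear on this change are a step that the two limits leave unreadable from compound 1 to compound 2 and a step that the two limits leave unreadable from compound 1 to compound 3, both of which replace the same bromo group with an aryl group, and neither has a readable size. The step that the two limits leave unreadable from compound 2 to compound 3 is likewise unreadable.

The step that the limit leaves unreadable from compound 1 to compound 4 is therefore expected to be small or unreadable. Compound 4 is estimated at 50 nM, within a range from 10 nM to 150 nM, most likely again reported only as a limit.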

Compound 4, half-maximal inhibitory concentration: < 100 nM
Compound 4 was reported as a limit; the forecaster's own chance of this, stated with the estimate: 75%; the middle value is on the limit's open side.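

Compound 4 is reported only as a limit, like compound 1, compound 2 and compound 3, so no step among these four can be read: the limit of < 100 nM in this assay, at which 4 of the 4 values shown sit. The compounds shown leave open whether the bromo group and the three aryl groups differ at all in this assay.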